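Moving the methyl on the benzamide ring

The source may hold more compounds than are shown below. What is called first, only, known or untested is meant among the compounds shown, and "the series" means these compounds.

Measured compounds:
compound 1 `O=C(Nc1cccc(/C=C/C(=O)c2nc3ccccc3[nH]2)c1)c1cccc(Cl)c1`: 7840 nM
compound 2 `O=C(Nc1cccc(/C=C/C(=O)c2nc3ccccc3[nH]2)c1)c1cccc(Br)c1`: 5210 nM
compound 3 `Cc1cccc(C(=O)Nc2cccc(/C=C/C(=O)c3nc4ccccc4[nH]3)c2)c1`: 5590 nM

In a functional assay on MCF7 cells (Homo sapiens) for antiproliferative activity, read by MTT assay, with a stated time of 48 h (on this read-out higher numbers stand for weaker inhibition and lower numbers for stronger inhibition), compound 1 gives 7840 nM, compound 2 gives 5210 nM and compound 3 gives 5590 nM. Compound 2 holds the lowest of the three numbers, yet its separation from both neighbours is small: a 1.5-fold lower number from compound 1 to compound 2 (0.18 log units; within the scatter) and a 1.1-fold higher number from compound 2 to compound 3 (0.03 log units; within the scatter), and likewise a 1.4-fold lower number from compound 1 to compound 3 (0.15 log units; within the scatter). None of the three steps leaves the scatter, so no ranking among them can be claimed.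

Compound 4 `Cc1ccc(C(=O)Nc2cccc(/C=C/C(=O)c3nc4ccccc4[nH]3)c2)cc1` has not been measured. Against compound 2 the change is 4-methylphenyl in place of 3-bromophenyl on a carbonyl carbon. Two things happen at once: bromine gives way to methyl, and the substituent moves to a different carbon of the ring. The first part is covered by the measured step from bromo to methyl, a 1.1-fold higher number from compound 2 to compound 3 (0.03 log units; within the scatter), which stayed within the scatter. The second part, the shift of position, has no measured counterpart among these compounds, so nothing on record tells whether it matters. Given that every substituent swap on this ring so far stayed within the scatter, the step from compound 2 to compound 4 is expected to be small, a 1.2-fold higher number from compound 2 to compound 4 (0.06 log units; within the scatter). Compound 4 is therefore estimated at 6000 nM, within a range of 2500 nM to 15000 nM.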

Compound 4, half-maximal inhibitory concentration: 9690 nM
Compound 4: middle estimate off by 1.6-fold (0.21 log units), on the low side, and the stated range covers the measured number.
By their numbers in this assay, from the lowest: compounds 2, 3, 1 and 4 (each within the scatter of the next).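

Compound 3 and compound 4 give the first measured view of the shift of position alone, with the methyl kept and only the ring carbon carrying it changed: in this assay this swap gives a 1.7-fold higher number from compound 3 to compound 4 (0.24 log units; within the scatter). The two steps that also change the substituent stay inside the scatter too, with a 1.9-fold higher number from compound 2 to compound 4 (0.27 log units; within the scatter) and a 1.2-fold higher number from compound 1 to compound 4 (0.09 log units; within the scatter), so neither the kind of substituent nor the carbon it occupies has yet produced a difference that can be told apart from repeat measurement, even though the steps to compound 4 from compound 2 and compound 3 are the largest in this set. Nothing on record offers an explanation for these numbers.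

From the compounds shown here alone, whether a different group at this place, such as an amine, a carboxylic acid or a longer chain, would take the number beyond the scatter remains open. Also open, going by these compounds, is whether the shift of position would read the same with chloro or bromo in place of methyl, since only the methyl pair isolates it.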